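The source may hold more compounds than are shown below. What is called first, only, known or untested is meant among the compounds shown, and "the series" means these compounds.

Series values in a functional assay on DU-145 cells (Homo sapiens) for cytotoxicity, read by MTT assay; a higher number here means a weaker inhibitor, a lower number a stronger inhibitor:
- compound 1 `CCCC(O)CC(=O)O[C@H](CC=C(C)C)C1=CC(=O)c2c(O)ccc(O)c2C1=O`: > 100000 nM (a limit of the assay, not a number)
- compound 2 `CC(=O)OCCO[C@H](CC=C(C)C)C1=CC(=O)c2c(O)ccc(O)c2C1=O`: 15500 nM
- compound 3 `CCCC(CC(=O)O[C@H](CC=C(C)C)C1=CC(=O)c2c(O)ccc(O)c2C1=O)OC(C)=O`: 55700 nM

Of the two true numbers, the higher belongs to compound 3, at 55700 nM, while compound 2 gives 15500 nM. Compound 1 sits at the limit, (the limit of > 100000 nM in this assay, at which 1 of the 3 values shown sits).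

Compound 4 `CC(C)=CC[C@@H](OC(=O)CC(C)(O)C(C)C)C1=CC(=O)c2c(O)ccc(O)c2C1=O` is still unmeasured. It differs from compound 3 as follows: 1-hydroxy-1,2-dimethylpropyl in place of 1-acetoxybutyl on a saturated chain carbon bound to a carbonyl carbon. In words, 1-hydroxy-1,2-dimethylpropyl stands in place of 1-acetoxybutyl on a saturated chain carbon bound to a carbonyl carbon.

For the measured compounds named here, the closest precedent is the acetyl-for-hydrogen step, an at least 1.7-fold lower number from compound 1 to compound 3 (0.25 log units; that floor lies within the scatter), and compound 4 returns to a free hydroxyl, which is the reverse sense. The wider side-chain change, an at least 6.4-fold lower number from compound 1 to compound 2 (0.80 log units; beyond the scatter), bears on it less directly. A shift towards weaker inhibition in this assay is therefore expected, though it may not clear the scatter, and a reading at the limit is quite possible. The expected step is a 1.6-fold higher number from compound 3 to compound 4 (0.21 log units; within the scatter). For compound 4 the estimated value is 90000 nM, with an expected range from 40000 nM to 200000 nM.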

Compound 4, half-maximal inhibitory concentration: 16900 nM
Compound 4: the middle estimate sits 5.3-fold (0.73 log units) above what was measured; measured number below the stated range.
By their numbers in this assay, from the lowest: compounds 2 and 4 (each within the scatter of the next); then compound 3. At a limit, above all of these: compound 1.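

In this assay, on a saturated chain carbon bound to a carbonyl carbon, 1-hydroxy-1,2-dimethylpropyl in place of 1-acetoxybutyl gives a 3.3-fold lower number from compound 3 to compound 4 (0.52 log units; beyond the scatter), so a free hydroxyl here does not by itself mean a weak reading, which compound 1 alone had suggested. With a hydroxyl on both sides, 1-hydroxy-1,2-dimethylpropyl in place of 1-hydroxybutyl gives an at least 5.9-fold lower number from compound 1 to compound 4 (0.77 log units; beyond the scatter), which points to the rest of the side chain, while a 1.1-fold higher number from compound 2 to compound 4 (0.04 log units; within the scatter) leaves the two side chains level. The reading of compound 1 in that first step is a limit of the assay, not a number: the limit of > 100000 nM in this assay, at which 1 of the 4 values shown sits.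

Which part of 1-hydroxy-1,2-dimethylpropyl carries the step stays open, as its methyl groups and its chain differ from 1-hydroxybutyl together. From the compounds shown here alone, how an amine, a carboxylic acid or a longer chain would read at this place also stays open.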